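The compounds below may be only part of what the source reports. "The series", "measured", "known", "first", "only" and "open" are said of these compounds alone.

Measured compounds:

Compound 1, `COc1cc(Cl)cc(-c2nn(-c3cccc(NC(=O)Nc4ccc(Cl)c(C(F)(F)F)c4)c3)cc2-c2ccncc2)c1`: 96%
Compound 2, `COc1cc(Cl)cc(-c2nn(-c3cccc(NC(=O)Nc4cc(C(F)(F)F)cc(C(F)(F)F)c4)c3)cc2-c2ccncc2)c1`: 100%
Compound 3, `COc1cc(Cl)cc(-c2nn(-c3cccc(NC(=O)Nc4ccc(Cl)c(Cl)c4)c3)cc2-c2ccncc2)c1`: 100%

These three compounds share one core and differ only in the aryl group on the far end of the urea. In a functional assay on SF-539 cells (Homo sapiens) for inhibition, read by sulforhodamine B assay, with a stated time of 48 h, tested at 0.01 uM (a higher number here means a weaker effect of the compound at the concentration tested, a lower number a stronger effect), compound 3 gives 100%, which is level with compound 2 at the digits shown, and together these two are the highest of the three numbers. The step of a number 4 percentage points higher from compound 1 to compound 3 (within the scatter) is within the scatter, so compound 1 cannot be told apart from compound 3 on these numbers either; all three compounds show almost no effect at this concentration.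

Compound 4, `COc1cc(Cl)cc(-c2nn(-c3cccc(NC(=O)Nc4cccc(C(F)(F)F)c4)c3)cc2-c2ccncc2)c1`, is the next compound. It differs from compound 3 by 3-(trifluoromethyl)phenyl in place of 3,4-dichlorophenyl on an amide-type nitrogen. Within the data shown here, the only measured step that bears on this is a number 4 percentage points higher from compound 1 to compound 3 (within the scatter), in which chloro and trifluoromethyl were swapped on this same aromatic ring and nothing beyond the scatter followed. The change to compound 4 is of the same kind, and the expectation is therefore a step of a number 2 percentage points lower from compound 3 to compound 4 (within the scatter), nothing beyond the scatter. For compound 4 in this assay the estimated value is 98%, with a range from 88% to 104%.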

Compound 4, a percentage reported as activity, at one concentration (the size of the read-out at that concentration, not a potency): 100%
Estimate against measurement, compound 4: 2 percentage points below; measured number inside the range.
By their numbers in this assay, from the lowest: compounds 1, 2, 3 and 4 (each within the scatter of the next).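

Compound 4 shows that the aryl group on the amide-type nitrogen can carry just one substituent, as 3-(trifluoromethyl)phenyl, without any readable shift in this assay. Set against the ring with two substituents, the numbers show this three ways: 3,4-dichlorophenyl gives way to it (no change at the digits printed from compound 3 to compound 4 (within the scatter)), hydrogen replaces a trifluoromethyl (no change at the digits printed from compound 2 to compound 4 (within the scatter)), and hydrogen replaces a chloro (a number 4 percentage points higher from compound 1 to compound 4 (within the scatter)). Why the four compounds sit so close together cannot be said, since no supporting evidence bears on this result.

On these data alone, all four numbers lie so near one another that this concentration separates none of these aryl groups, so whether they would differ at a higher concentration stays open. Also open, as far as these compounds go, is how this assay would respond to a far ring carrying an amine or a carboxylic acid, or to a plain unsubstituted phenyl.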